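Swapping the side-chain ester for a second fluorobenzyl group

A few compounds are considered here, and "the series" means these few. Any claim that something is new, unique, unknown or untested is made for them only; others in the source may bear on it.

Three compounds of the series have been run in a functional assay on MDA-MB-435 cells (Homo sapiens) for cytotoxicity, read by MTT assay, with a stated time of 72 h; on this read-out lower numbers stand for stronger inhibition and higher numbers for weaker inhibition. Compound 1, `C[C@@H](CO)Nc1nc(C(=O)NCc2ccc(F)cc2)c(O)c2ncccc12`, gives only a limit in this assay, at > 20000 nM. Compound 3, `N[C@H]1CC[C@H](Nc2c(C(=O)NC3CCCCC3)nc(Br)c3cccnc23)CC1`, likewise gives only a limit in this assay, at > 10000 nM. Among the compounds with values here, compound 2, `COC(=O)CNc1c(C(=O)NCc2ccc(F)cc2)nc(Br)c2cccnc12`, is the one member of the set with an actual number in this assay, at 10000 nM. Within the data shown here, no step between two measured compounds that differ in one place is available, so the series offers no measured guide for the move to compound 4.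

Compound 4, `O=C(NCc1ccc(F)cc1)c1nc(Br)c2cccnc2c1NCc1ccc(F)cc1`, is not yet measured in this assay. It differs from compound 2 as follows: 4-fluorophenyl in place of methoxycarbonyl on a saturated chain carbon bound to a nitrogen on an aromatic ring. Among the measured compounds shown here, with no comparable measured step in hand, the expectation for compound 4 in this assay is a change that stays within, or barely beyond, the usual scatter, a 1.3-fold lower number from compound 2 to compound 4 (0.10 log units; within the scatter). The value for compound 4 is therefore estimated at 8000 nM, with a plausible range from 2500 nM to 25000 nM; a reported limit rather than a number remains a real possibility.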

Compound 4, half-maximal inhibitory concentration: > 20000 nM
Compound 4 was reported as a limit; the forecaster's own chance of this, stated with the estimate: 35%; middle value at least 2.5-fold (0.39 log units) from the limit.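

In this assay compound 4 gives > 20000 nM as its reading, which is a limit and not a number. The step reads an at least 2.0-fold higher number from compound 2 to compound 4 (0.30 log units; that floor lies within the scatter) and is only a floor: 4-fluorophenyl in place of methoxycarbonyl on this saturated chain carbon brings no measurable gain, while a real loss is neither shown nor excluded. Within the data shown here, compound 2 therefore remains the only member of the set with an actual number, and the new reading joins the upper limit of the series: the limit of > 20000 nM in this assay, at which 2 of the 4 values shown sit.

Still open, as far as these compounds go, is where the true value of compound 4 lies, and so whether the change costs anything at all. Equally open, from the compounds shown here alone, is whether a carboxylic acid, a longer chain ester or an unsubstituted benzyl group on this side chain would give a measurable value.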